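The source may report more compounds than this note shows. Statements on the series, on what has been measured and on what is new or still open speak of the compounds shown alone.

Measured in an assay on microsomes from intestine for inhibition of acyl-CoA:cholesterol acyltransferase (Oryctolagus cuniculus); on this read-out lower numbers stand for stronger inhibition and higher numbers for weaker inhibition:
compound 1, `CC(C)c1cccc(C(C)C)c1NC(=O)NC(=O)N(Cc1ccccc1)C(C)C`: 750 nM.
compound 2, `CC(C)c1cccc(C(C)C)c1NC(=O)NC(=O)N1CCCC1`: > 5000 nM.
compound 3, `CCCCCCCCN(CCCCCCCC)C(=O)NC(=O)Nc1c(C(C)C)cccc1C(C)C`: 350 nM.

For compound 2 only a limit is recorded, > 5000 nM, which is the limit of > 5000 nM in this assay, at which 1 of the 3 values shown sits, and not a number. Compound 4, `CCCCCC(C)OC(=O)NC(=O)Nc1c(C(C)C)cccc1C(C)C`, differs from compound 2 by (1-methylhexyl)oxy in place of pyrrolidin-1-yl on a carbonyl carbon. Among the compounds with values here, no measured pair covers this change, so the size of the step is not known from the data. Compound 1 gives 750 nM and compound 3 gives 350 nM, and both carry open-chain groups rather than a ring, so for compound 4 a downward step, beyond the scatter, is expected in this assay, an at least 5.5-fold lower number from compound 2 to compound 4 (0.74 log units; beyond the scatter). Compound 4 is estimated at 900 nM, with a range from 250 nM to 3500 nM.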

Compound 4, half-maximal inhibitory concentration: 1060 nM
Beside the measured number, compound 4's estimate is 1.2-fold (0.07 log units) below it; measured number inside the range.
By their numbers in this assay, from the lowest: compound 3; then compounds 1 and 4 (each within the scatter of the next). At a limit, above all of these: compound 2.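

In this assay, within the data shown here, a group joined through oxygen on a carbonyl carbon whose other neighbour is the amide-type nitrogen is compatible with a measurable number, whereas the earlier compounds all carry nitrogen groups there: (1-methylhexyl)oxy in place of pyrrolidin-1-yl gives an at least 4.7-fold lower number from compound 2 to compound 4 (0.67 log units; beyond the scatter). Compound 2 stands only at a limit, so the true size of this step stays unknown: the limit of > 5000 nM in this assay, at which 1 of the 4 values shown sits.

The change alters the linking atom and replaces a ring with an open chain at once, and the compounds shown do not separate the two. A cyclopentyloxy group or a diethylamino group at this place would separate them.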